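The source may report more compounds than this note shows. Statements on the series, on what has been measured and on what is new or still open speak of the compounds shown alone.

Measured so far in a functional assay on HL-60 cells (Homo sapiens) for cytotoxicity, read by MTT assay, with a stated time of 46 h; a lower number here means a stronger inhibitor, a higher number a weaker inhibitor:
- compound 1 `O=C1/C(=C\c2ccncc2)C(c2ccccc2)Oc2ccccc21`: 1100 nM
- compound 2 `O=C1/C(=C/c2ccc(Br)cc2)C(c2ccccc2)Oc2ccccc21`: 5700 nM

Compound 2 has the higher of the two numbers in this assay, making it the weaker inhibitor of the pair, and its gap to compound 1 lies beyond the usual scatter. These two compounds differ in more than one place, so the gap says nothing about any single change.

The next compound to be measured is compound 3 `O=C1/C(=C\c2ccc(Br)cc2)C(c2ccccc2)Oc2ccccc21`. Its difference from compound 2 is confined to the double bond: the two compounds have the same atoms and bonds; at least one stereo element is drawn with a configuration in one of them and without one in the other: 1 of 2 stereo elements differ; a double bond is drawn E in compound 2 and Z in compound 3. Among the measured compounds shown here, no measured pair differs only in this way, so the data give no direct size for such a change. In this assay, the expectation is therefore no step beyond the scatter, with a slight lean toward a lower number. For the measured compounds named here, the range stays wide, since the only measured gap is the one separating compound 2 at 5700 nM from compound 1 at 1100 nM.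

The estimate corresponds to an expected 1.4-fold lower number from compound 2 to compound 3 (0.15 log units; within the scatter).

For compound 3 the estimated value is 4000 nM, with an expected range from 1300 nM to 12000 nM.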

Compound 3, half-maximal inhibitory concentration: > 1000000 nM
Compound 3: only a limit was reported; the forecaster's own chance of this, stated with the estimate: 5%; at least 250-fold (2.39 log units) between middle value and limit.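

In this assay compound 3 carries only a limit, > 1000000 nM. With atoms and bonds unchanged, the double bond alone accounts for an at least 170-fold higher number from compound 2 to compound 3 (2.24 log units; beyond the scatter), so the drawn configuration at this position can matter far more in this series than compounds 1 and 2 could show, as they differ in more than one place. With the double bond drawn alike, 4-bromophenyl in place of pyridin-4-yl on the double-bonded chain carbon accounts for an at least 900-fold higher number from compound 1 to compound 3 (2.95 log units; beyond the scatter), which gives the aryl group a separate single-change reading, and both steps are minimum sizes set by a limit: the limit of > 1000000 nM in this assay, at which 1 of the 3 values shown sits.

Still open, on these data alone, is how the pyridin-4-yl group behaves with the double bond as drawn in compound 2, so it cannot yet be said whether the configuration step holds for aryl groups other than 4-bromophenyl, and the reading of that step also rests on how the two compounds are drawn: the fact that one of compounds 2 and 3 is drawn with a defined configuration and the other without, at the place where they differ Equally open is whether an amine or a carboxylic acid in place of the bromine would keep the number of compound 2 or follow compound 3 toward the limit.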